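Configuration change from compound 3 to compound 4

The source may report more compounds than this note shows. Statements on the series, on what has been measured and on what is new or still open speak of the compounds shown alone.

Measured so far in a functional assay on BXPC-3 cells (Homo sapiens) for antiproliferative activity, read by MTT assay, with a stated time of 24 h (on this read-out lower numbers stand for stronger inhibition and higher numbers for weaker inhibition), for three compounds:
compound 1 `CCn1c(C(=O)NCCN)ccc1C(CC)(CC)c1ccc(OCS(=O)(=O)c2ccccc2)c(C)c1` (6430 nM)
compound 2 `CCn1c(C(=O)NCCCO)ccc1C(CC)(CC)c1ccc(OCS(=O)(=O)c2ccccc2)c(C)c1` (26600 nM)
compound 3 `CCn1c(C(=O)N[C@H](CO)CCO)ccc1C(CC)(CC)c1ccc(OCS(=O)(=O)c2ccccc2)c(C)c1` (15900 nM)

Compound 3 holds the second highest of the three numbers. It lies within the scatter of compound 2, as shown by a 1.7-fold lower number from compound 2 to compound 3 (0.22 log units; within the scatter) and is set apart from compound 1, as shown by a 2.5-fold higher number from compound 1 to compound 3 (0.39 log units; beyond the scatter) in a modest step.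

Compound 4 `CCn1c(C(=O)N[C@@H](CO)CCO)ccc1C(CC)(CC)c1ccc(OCS(=O)(=O)c2ccccc2)c(C)c1` keeps the same atoms and bonds: the two compounds have the same atoms and bonds and differ only in configuration as drawn: 1 of 1 stereo elements differ; a stereocentre at a saturated chain carbon is drawn S in compound 3 and R in compound 4 and so a stereocentre at a saturated chain carbon is drawn S in compound 3 and R in compound 4.

For the measured compounds named here, no measured step is a change of configuration alone, so none gives its size directly. The measured changes on this chain are small, the largest being a 4.1-fold higher number from compound 1 to compound 2 (0.62 log units; beyond the scatter) and still modest. In this assay no step beyond the scatter is expected, and no direction can be named. The estimated step is a 1.1-fold lower number from compound 3 to compound 4 (0.03 log units; within the scatter) as an expectation only. For compound 4 the estimated value is 15000 nM with an expected range from 6500 nM to 35000 nM on present data.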

Compound 4, half-maximal inhibitory concentration: > 50000 nM
Compound 4: no number, only a limit; the forecaster's own chance of this, stated with the estimate: 3%; at least 3.3-fold (0.52 log units) between middle value and limit.
By their numbers in this assay, from the lowest: compound 1; then compounds 3 and 2 (each within the scatter of the next). At a limit, above all of these: compound 4.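

In this assay compound 4 gives > 50000 nM, which is a limit and not a number. Configuration alone at this saturated chain carbon gives an at least 3.1-fold higher number from compound 3 to compound 4 (0.49 log units; beyond the scatter), so this stereocentre is not neutral in this assay, which the earlier compounds, each with a different chain, could not show: the fact that compounds 3 and 4 differ only in the configuration as drawn. The other two steps are floors as well, an at least 1.8-fold higher number from compound 2 to compound 4 (0.27 log units; that floor lies within the scatter) and an at least 7.7-fold higher number from compound 1 to compound 4 (0.89 log units; beyond the scatter), and all three are bounded by the same assay limit: the limit of > 50000 nM in this assay, at which 1 of the 4 values shown sits.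

As far as these compounds go, how far compound 4 lies beyond its limit stays open, and with it the full size of the step from configuration. Also open, from the compounds shown here alone, is whether inverting this stereocentre has a similar result when an amine or a carboxylic acid stands in place of the hydroxymethyl group.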